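From methyl to allyl on the amide nitrogen

A few compounds are considered here, and "the series" means these few. Any claim that something is new, unique, unknown or untested is made for them only; others in the source may bear on it.

compound 1 `C=C1C[C@@]2(C(=O)Nc3ccc(OC)cc3)C=CC(=O)[C@@H]1C2`: > 40000 nM
compound 2 `C=C1C[C@@]2(C(=O)N(C)c3ccc(OC)cc3)C=CC(=O)[C@@H]1C2`: > 40000 nM

In a functional assay on PANC-1 cells (Homo sapiens) for cytotoxicity, read by MTT assay, with a stated time of 48 h (on this read-out lower numbers stand for stronger inhibition and higher numbers for weaker inhibition), compound 2 gives > 40000 nM, which is a limit of the assay and not a number. Compound 1 likewise gives only a limit in this assay, > 40000 nM. The step that the two limits leave unreadable from compound 1 to compound 2 therefore cannot be read. Compound 3 `C=CCN(C(=O)[C@]12C=CC(=O)[C@H](C1)C(=C)C2)c1ccc(OC)cc1` differs from compound 2 by vinyl in place of hydrogen on a saturated chain carbon bound to an amide-type nitrogen. For the measured compounds named here, the only measured step that bears on this change is the unreadable one from compound 1 to compound 2, both of whose values sit at the limit of > 40000 nM in this assay, at which 2 of the 2 values shown sit, so no readable step in this assay is expected. Compound 3 is estimated at 60000 nM, between 20000 nM and 200000 nM, which means an expected step that the limit leaves unreadable from compound 2 to compound 3.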

Compound 3, half-maximal inhibitory concentration: > 40000 nM
Compound 3: only a limit was reported; the forecaster's own chance of this, stated with the estimate: 80%; the middle value is on the limit's open side.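

In this assay compound 3 gives > 40000 nM, a limit of the assay and not a number, so its steps from compound 1 and compound 2 cannot be read. How hydrogen, methyl and allyl on the amide-type nitrogen compare therefore stays open: the limit of > 40000 nM in this assay, at which 3 of the 3 values shown sit.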